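From chloro to methyl on compound 1

A few compounds are considered here, and "the series" means these few. Any claim that something is new, unique, unknown or untested is made for them only; others in the source may bear on it.

Within the data shown here, in a functional assay on HCT-116 cells (Homo sapiens) for antiproliferative activity, read by MTT assay, with a stated time of 48 h (a higher number here means a weaker inhibitor, a lower number a stronger inhibitor), compound 1 (`O=C(/C=C/c1ccc(/C=C/C(=O)c2ccc(Cl)cc2)o1)NO`) gives 2010 nM and holds the lower of the two numbers so far. Compound 2 (`O=C(NO)c1ccc(/C=C/c2ccccc2O)o1`) gives 5100 nM on the same read-out, a gap beyond the scatter. Compound 3 (`Cc1ccc(C(=O)/C=C/c2ccc(/C=C/C(=O)NO)o2)cc1`) has methyl in place of chloro on an aromatic carbon and otherwise keeps the core of compound 1. Among the measured compounds shown here, no measured pair shows this change, so no step beyond the scatter is expected in this assay (a 1.2-fold higher number from compound 1 to compound 3 (0.09 log units; within the scatter)) for this swap. For compound 3 the estimated value is 2500 nM with 1000 nM to 6000 nM as the expected range.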

Compound 3, half-maximal inhibitory concentration: 540 nM
For compound 3 the middle estimate is 4.6-fold (0.67 log units) above the measured one; the whole stated range lies above it.
By their numbers in this assay, from the lowest: compound 3; then compound 1; then compound 2.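

The swap of 4-chlorophenyl to 4-methylphenyl gives a 3.7-fold lower number from compound 1 to compound 3 (0.57 log units; beyond the scatter) in this assay and is the only single-place step shown, so this position does affect the read-out. Chloro and methyl each count one heavy atom, with no ring, charge, hydrogen-bond donor or acceptor, yet the step lies beyond the scatter. Nothing measured here accounts for the step.

The compounds shown leave open whether the lower number is particular to methyl. From the compounds shown here alone, how a methoxy group, an amine or a longer chain such as ethyl would compare on this aromatic carbon also remains open.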